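A few compounds are considered here, and "the series" means these few. Any claim that something is new, unique, unknown or untested is made for them only; others in the source may bear on it.

Working notes on the series. In a functional assay on HL-60 cells (Homo sapiens) for antiproliferative activity, read by trypan blue exclusion (on this read-out lower numbers stand for stronger inhibition of growth and higher numbers for weaker inhibition of growth), compound 1 (`C=C1[C@@H](CCC2=CCOC2=O)[C@]2(C)CC[C@@H](O)[C@@](C)(CO)[C@H]2C[C@@H]1O`) gives 25200 nM and compound 2 (`C=C1CC[C@H]2[C@@](C)(CCC(=O)[C@@]2(C)CO)[C@@H]1CCC1=CCOC1=O`) gives 22800 nM. These two values lie within the usual scatter, so compound 2 stands level with compound 1 and both sit in the same high range of concentrations.

Compound 3 (`C=C1CC[C@H]2[C@@](C)(CCC(=O)[C@@]2(C)CO)[C@@H]1/C=C/C1=CCOC1=O`) keeps the core of compound 2 and changes one group: a group of 8 heavy atoms (6 carbon, 2 oxygen; one five-membered non-aromatic ring with 1 hetero atom) in place of a group of 8 heavy atoms (6 carbon, 2 oxygen; one five-membered non-aromatic ring with 1 hetero atom), on a saturated ring carbon. The change sits on a saturated ring carbon of a six-membered non-aromatic ring of carbon only, part of a fused or bridged system of two rings. The five-membered non-aromatic ring with 1 hetero atom remains in the group that enters.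

For the measured compounds named here, no measured step matches this change, so there is nothing to scale the expectation from, and it stays loose. The expected step is a 1.6-fold lower number from compound 2 to compound 3 (0.21 log units; within the scatter) in this assay, a modest move toward stronger inhibition of growth that is not expected to go clearly beyond the scatter. No change at all would not be a surprise. For compound 3 the estimate is 14000 nM, with an expected range of 5000 nM to 35000 nM.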

Compound 3, concentration for 50% growth inhibition: 19200 nM
Estimate against measurement, compound 3: 1.4-fold (0.14 log units) below, and the stated range covers the measured number.
By their numbers in this assay, from the lowest: compounds 3, 2 and 1 (each within the scatter of the next).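

In this assay, the group with 3 double bonds outside aromatic rings, in place of the group with 2, gives a 1.2-fold lower number from compound 2 to compound 3 (0.07 log units; within the scatter). For the compounds shown here, this is the first step that can be read on a saturated ring carbon of a six-membered non-aromatic ring of carbon only, and it shows that this change in the group, with the five-membered non-aromatic ring with 1 hetero atom kept, leaves compound 3 level with compound 2 and in the same high range of concentrations. No measurement of any property of the two groups accompanies this result, so the level outcome stands without an explanation.

Going by these compounds, whether the five-membered non-aromatic ring with 1 hetero atom is needed at this place stays open, as does whether a longer chain, an amine or a carboxylic acid in its stead would move the number beyond the scatter. Compound 1 differs from compound 2 in more than one place, so the compounds shown hold no single step for any other place on the shared core, and what such changes would do remains open as well.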